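Removing the benzyl group from the rhodanine-dienyl series

A few compounds are considered here, and "the series" means these few. Any claim that something is new, unique, unknown or untested is made for them only; others in the source may bear on it.

Of the compounds shown here, three sharing one core have been tested in a functional assay on DLD-1 cells (Homo sapiens), read by microscopy and crystal violet staining, with a stated time of 20 h, tested at 10 ug/mL; a lower number here means less inhibition, a higher number more inhibition at the concentration tested (going by the name of the read-out). Compound 1 `COc1ccccc1COc1ccccc1/C=C/C=C1\SC(=S)NC1=O` gives 98%, compound 2 `O=C1NC(=S)S/C1=C\C=C\c1ccccc1OCc1ccccc1C(F)(F)F` gives 80%, and compound 3 `O=C1NC(=S)S/C1=C\C=C\c1ccccc1OCc1ccccc1` gives 65%. Compound 3 therefore stands lowest of the three, with its steps to both others beyond the scatter. The measured steps all concern the group on the outer aromatic ring of the benzyl: a number 18 percentage points lower from compound 1 to compound 2 (beyond the scatter), a number 33 percentage points lower from compound 1 to compound 3 (beyond the scatter) and a number 15 percentage points lower from compound 2 to compound 3 (beyond the scatter). Each time the group on that ring was made smaller, the inhibition fell.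

Compound 4 `O=C1NC(=S)S/C1=C\C=C\c1ccccc1O` goes one stage further: hydrogen in place of benzyl on an oxygen on an aromatic ring. For the measured compounds named here, no measured step removes the benzyl itself, so this is an extrapolation. The direction of the three steps suggests that taking away the whole benzyl lowers the inhibition again, and a modest to large fall, a number 20 percentage points lower from compound 3 to compound 4 (beyond the scatter), is expected. Compound 4 is thus estimated at 45%, within a range of 15% to 75%.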

Compound 4, a percentage reported as inhibition, at one concentration (the size of the read-out at that concentration, not a potency): 65%
Compound 4: the middle estimate sits 20 percentage points below what was measured; measured number inside the range.
By their numbers in this assay, from the lowest: compounds 3 and 4 (each within the scatter of the next); then compound 2; then compound 1.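

In this assay, hydrogen in place of benzyl on an oxygen on an aromatic ring gives no change at the digits printed from compound 3 to compound 4 (within the scatter), so the unsubstituted benzyl can leave this oxygen without a change beyond the scatter. For the compounds shown here, the earlier steps showed only that the group on the outer ring of the benzyl matters; this step shows that the falls seen along those steps do not carry on once the whole benzyl is gone. Nothing measured here bears on the cause of this result.

The compounds shown leave open how a methyl group, a longer alkyl chain or a carboxylic acid on this same oxygen would compare with the hydroxy of compound 4. They also leave open whether compound 3 and compound 4 would still match at other concentrations, as this read-out reports a single concentration and not a potency.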